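This account rests on a few compounds, and the source may have more. Where it says the series, first, only, none or still open, it means among the compounds named here.

Measured so far:
compound 1 `O=C(/C=C/c1ccc2c(c1)B(O)OC2)c1ccc(I)cc1` — 11600 nM
compound 2 `Cc1ccc(C(=O)/C=C/c2ccc3c(c2)B(O)OC3)cc1` — 10500 nM
compound 3 `O=C(/C=C/c1ccc2c(c1)B(O)OC2)c1ccc(O)cc1` — 24100 nM

In a functional assay on HCT-116 cells (Homo sapiens) for cytotoxicity, read by MTT assay, with a stated time of 48 h (on this read-out lower numbers stand for stronger inhibition and higher numbers for weaker inhibition), compound 3 stands at the highest of the three numbers: the step of a 2.1-fold higher number from compound 1 to compound 3 (0.32 log units; beyond the scatter) and the step of a 2.3-fold higher number from compound 2 to compound 3 (0.36 log units; beyond the scatter) both run upward beyond the scatter, while the step of a 1.1-fold lower number from compound 1 to compound 2 (0.04 log units; within the scatter) stays within it. Compound 4 `O=C(/C=C/c1ccc2c(c1)B(O)OC2)c1cccc(F)c1` differs from compound 3 by 3-fluorophenyl in place of 4-hydroxyphenyl on a carbonyl carbon. Among the measured compounds shown here, the two steps into compound 3 bear on this change, since each replaced another substituent with hydroxy and each raised the number modestly; taking the hydroxy away is therefore expected to lower the number by a similar modest amount, although no measured compound carries a 3-fluorophenyl, so that part of the change is untested. Compound 4 is accordingly expected to give 12000 nM, between 6000 nM and 25000 nM, an expected step of a 2.0-fold lower number from compound 3 to compound 4 (0.30 log units; within the scatter).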

Compound 4, half-maximal inhibitory concentration: 6700 nM
Beside the measured number, compound 4's estimate is 1.8-fold (0.25 log units) above it, within the range that was stated.
By their numbers in this assay, from the lowest: compounds 4, 2 and 1 (each within the scatter of the next); then compound 3.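

In this assay, 3-fluorophenyl in place of 4-hydroxyphenyl on the carbonyl carbon gives a 3.6-fold lower number from compound 3 to compound 4 (0.56 log units; beyond the scatter), a step beyond the scatter. The other two steps, a 1.6-fold lower number from compound 2 to compound 4 (0.20 log units; within the scatter) and a 1.7-fold lower number from compound 1 to compound 4 (0.24 log units; within the scatter), stay within the scatter, so 3-fluorophenyl joins 4-methylphenyl and 4-iodophenyl as a group that cannot be separated from them, while compound 3 alone stands apart. No evidence is available that explains this difference.

From the compounds shown here alone, the change alters both the substituent and its ring position, so the contribution of each remains open. Going by these compounds, it is also open whether 4-fluorophenyl or 3-hydroxyphenyl would read like compound 4 or like compound 3.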